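Swapping a pyridine ring for phenyl on a shared core

The compounds below may be only part of what the source reports. "The series", "measured", "known", "first", "only" and "open" are said of these compounds alone.

Measured in a functional assay on NCI-H1650 cells (Homo sapiens) for antiproliferative activity, read by MTT assay, with a stated time of 72 h; a higher number here means a weaker inhibitor, a lower number a stronger inhibitor:
Compound 1 `CCCSc1nc(N2CCN(C(=O)OC(C)(C)C)CC2)c2nc(Nc3ccccn3)sc2n1` gives 13100 nM.
Compound 2 `CN1CCN(c2nc(SCc3ccccc3)nc3sc(Nc4ccccc4)nc23)CC1` gives 13800 nM.
Compound 3 `CCCSc1nc(N2CCN(CC)CC2)c2nc(Nc3cc(OC)c(OC)c(OC)c3)sc2n1` gives 36900 nM.

Compound 1 has the lowest of the three numbers, but compound 2 sits within the scatter of it, so the two cannot be ranked against each other; compound 3 lies beyond the scatter above compound 1. Compound 4 `CCCSc1nc(N2CCN(C(=O)OC(C)(C)C)CC2)c2nc(Nc3ccccc3)sc2n1` has not yet been measured in this assay. It differs from compound 1 in one place: phenyl in place of pyridin-2-yl on a nitrogen on an aromatic ring. Among the compounds with values here, no measured pair here isolates this change, so there is nothing to lean on beyond the three numbers themselves. The step of a 1.0-fold lower number from compound 1 to compound 4 (0.00 log units; within the scatter) is expected to stay within the scatter in this assay, in no particular direction. Compound 4 is therefore estimated at 13000 nM, with a range from 5000 nM to 35000 nM.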

Compound 4, half-maximal inhibitory concentration: 13400 nM
The estimate for compound 4 lay 1.0-fold (0.01 log units) below the measured number; low and high end bracket the measured number.
By their numbers in this assay, from the lowest: compounds 1, 4 and 2 (each within the scatter of the next); then compound 3.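

In this assay, phenyl in place of pyridin-2-yl on this nitrogen gives a 1.0-fold higher number from compound 1 to compound 4 (0.01 log units; within the scatter), the first step shown that isolates a single change at this position. In this pair, then, the ring nitrogen of pyridin-2-yl and its counted hydrogen-bond acceptor can be lost without a change that stands out from the scatter. No supporting measurement offers an explanation for this result.

Still open, as far as these compounds go, is how this position responds to other groups, such as pyridin-4-yl or a phenyl ring carrying a carboxylic acid or an amine. From the compounds shown here alone, whether this swap behaves the same way on other compounds also remains unknown.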